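The source may report more compounds than this note shows. Statements on the series, on what has been measured and on what is new or still open speak of the compounds shown alone.

Compound 3 `O=C(Nc1ccc2c(c1)B(O)OC2)c1ccccc1Cl` is known in a functional assay on PBMC cells (Homo sapiens) for inhibition, read by HTRF, with stated times of 15 min and 24 h (a lower number here means a stronger inhibitor, a higher number a weaker inhibitor), only by a limit of the assay and not by a number: compound 3 gives > 100000 nM. The two related compounds stand in the same way. Compound 1 `O=C(Nc1ccc2c(c1)B(O)OC2)c1ccccc1` gives > 100000 nM in this assay, which is again a limit. Compound 2 `O=C(Nc1ccc2c(c1)B(O)OC2)c1ccccc1F` gives > 10000 nM in this assay, also a limit. The steps among these three compounds therefore cannot be read: a step that the two limits leave unreadable from compound 1 to compound 2, a step that the two limits leave unreadable from compound 1 to compound 3 and a step that the two limits leave unreadable from compound 2 to compound 3. Of the three values shown, two sit at the limit of > 100000 nM in this assay, at which 2 of the 3 values shown sit, and one at the limit of > 10000 nM in this assay, at which 1 of the 3 values shown sits, so nothing places any of the three compounds above or below the others.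

Compound 4 `COc1ccccc1C(=O)Nc1ccc2c(c1)B(O)OC2` differs from compound 3 in one place: methoxy in place of chloro on an aromatic carbon. Within the data shown here, no measured step bears on the exchange of chloro for methoxy, and the three steps that are known give no size in either direction. Among the measured compounds shown here, with every value so far a limit, compound 4 is expected to give about 100000 nM in this assay, within a range from 20000 nM to 500000 nM, and most probably as a limit once more. The step expected in this assay is therefore a number no higher from compound 3 to compound 4 (the limit leaves the size open), with no change beyond the scatter anticipated.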

Compound 4, half-maximal inhibitory concentration: > 100000 nM
Compound 4 gave a limit, no number; the forecaster's own chance of this, stated with the estimate: 85%; the middle value sits exactly at the limit.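

In this assay compound 4 gives > 100000 nM, which is a limit and not a number. Among these compounds, no step from compound 1, compound 2 or compound 3 to compound 4 can be read. The four compounds leave open how strongly any of them inhibits, and whether hydrogen, fluoro, chloro or methoxy at this place makes any difference in this assay.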